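Leaving the 4-methoxyphenyl group: compound 2 to compound 3

This account rests on a few compounds, and the source may have more. Where it says the series, first, only, none or still open, it means among the compounds named here.

In a functional assay (Pituitary gland cell) with Rattus norvegicus as the target (on this read-out lower numbers stand for an effect already at smaller amounts and higher numbers for an effect only at larger amounts of compound), compound 1 `CCNC(=O)c1ccccc1-c1ccc(CN2C(=O)[C@H](NC(=O)CC(C)(C)N)CCc3ccccc32)cc1` gives 0.09 uM and compound 2 `COc1ccc(CNC(=O)c2ccccc2-c2ccc(CN3C(=O)[C@H](NC(=O)CC(C)(C)N)CCc4ccccc43)cc2)cc1` gives 2 uM, so compound 2 holds the higher of the two numbers. Compound 3 `CC(C)(N)CC(=O)N[C@@H]1CCc2ccccc2N(Cc2ccc(-c3ccccc3C(=O)NCCO)cc2)C1=O` differs from compound 2 as follows: hydroxymethyl in place of 4-methoxyphenyl on a saturated chain carbon bound to an amide-type nitrogen. This places hydroxymethyl in place of 4-methoxyphenyl on a saturated chain carbon bound to an amide-type nitrogen, which also reads as 4-methoxybenzyl to 2-hydroxyethyl.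

For the measured compounds named here, only one measured step bears on this change. It concerns the same place and the same 4-methoxyphenyl group: a 22-fold higher number from compound 1 to compound 2 (1.35 log units; beyond the scatter), a large step beyond the scatter. Removing that group should therefore give a large step to a lower number in this assay. Going by the values given here, no measurement yet compares hydroxymethyl with methyl here, so the range stays wide. The expected change is a 13-fold lower number from compound 2 to compound 3 (1.12 log units; beyond the scatter). For compound 3 the estimated value is 0.15 uM, with an expected range of 0.05 uM to 0.6 uM.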

Compound 3, concentration for half-maximal effect: 3 uM
Estimate against measurement, compound 3: 20-fold (1.30 log units) below, and the stated range ends below it.
By their numbers in this assay, from the lowest: compound 1; then compounds 2 and 3 (each within the scatter of the next).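

In this assay, the change from 4-methoxybenzyl to 2-hydroxyethyl gives a 1.5-fold higher number from compound 2 to compound 3 (0.18 log units; within the scatter), so these two very different groups cannot be told apart at this position, and taking away the 4-methoxyphenyl group does not by itself return the number of compound 1. The terminal hydroxy group alone separates the ethyl amide from its 2-hydroxyethyl counterpart, with a 33-fold higher number from compound 1 to compound 3 (1.52 log units; beyond the scatter), which makes this chain end sensitive to a single added oxygen. No available data bear on the reason for this.

Still open, going by these compounds, is whether a 2-methoxyethyl, 2-aminoethyl or carboxymethyl group on the amide nitrogen would behave like the ethyl group or like the 2-hydroxyethyl group. A propyl chain or a plain benzyl group would also show how far the low number of compound 1 extends.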